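This account rests on a few compounds, and the source may have more. Where it says the series, first, only, none or still open, it means among the compounds named here.

Working notes on the series.

The series is read in a functional assay on the whole organism (strain albino) for inhibition, with Rattus norvegicus as the target, read by paw edema, with stated times of 1 h and 3 h, at a dose of 25 mg/kg by the oral route; on this read-out lower numbers stand for less inhibition and higher numbers for more inhibition at the one dose given (going by the name of the read-out). Compound 1, `CC1=C(C(=O)Nc2ccc(F)cc2)C(c2ccc([N+](=O)[O-])cc2)n2c(s/c(=C/c3ccc(Cl)cc3Cl)c2=O)=N1`, gives 17% in this assay. Compound 2, `CC1=C(C(=O)Nc2ccc(F)cc2)C(c2ccc(Cl)cc2)n2c(s/c(=C/c3ccc(Cl)cc3Cl)c2=O)=N1`, gives 14% in this assay. Compound 3, `CC1=C(C(=O)Nc2ccc(F)cc2)C(c2ccc(F)cc2)n2c(s/c(=C/c3ccc([N+](=O)[O-])cc3)c2=O)=N1`, gives 30% in this assay, the highest of the three numbers; its gap to compound 1 and to compound 2 is beyond the scatter in each case.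

One counted step is available. From compound 1 to compound 2 the change is chloro in place of nitro on an aromatic carbon, and the result is a number 3 percentage points lower from compound 1 to compound 2 (within the scatter): a step that stays within the scatter, so the two numbers show no change that can be relied on.

Compound 4, `CC1=C(C(=O)Nc2ccc(F)cc2)C(c2ccc(F)cc2)n2c(s/c(=C/c3ccc(Cl)cc3)c2=O)=N1`, has not yet been measured in this assay. Among the measured compounds shown here, it differs from compound 3 by chloro in place of nitro on an aromatic carbon, the same change as the one from compound 1 to compound 2, made here on the core of compound 3. The difference between the core of compound 1 and the core of compound 3 is not broken down here.

Given that the one measured instance of this change, a number 3 percentage points lower from compound 1 to compound 2 (within the scatter), moved the number only within the scatter, the expected step for compound 4 is also small, a number 3 percentage points lower from compound 3 to compound 4 (within the scatter), with no reason from the data to expect a shift in either direction beyond the scatter. Compound 4 is therefore estimated at 27%, within a range from 16% to 38%.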

Compound 4, a percentage reported as inhibition, in the whole organism at one dose (the size of the read-out at that dose, not a potency): 47%
For compound 4 the middle estimate is 20 percentage points below the measured one; measured number outside the range, above it.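

On the core of compound 3, chloro in place of nitro on an aromatic carbon gives a number 17 percentage points higher from compound 3 to compound 4 (beyond the scatter) in this assay, so on this core the change is followed by a real rise in the read-out. Set beside the earlier step, the same change does not carry from one core to the other with one size of step: the same change on two cores in this assay, a number 3 percentage points lower (within the scatter) from compound 1 to compound 2 and a number 17 percentage points higher (beyond the scatter) from compound 3 to compound 4, 20 percentage points apart, beyond the scatter of two such steps This shows that a step measured on the core of compound 1 cannot simply be applied to the core of compound 3, but with only two pairs it gives no general rule for the series and does not show which feature of the two cores accounts for the gap.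

On these data alone, it remains open which of the differences between the core of compound 1 and the core of compound 3 governs the size of the step, a question that pairs differing in one place at a time could answer. Also open, as far as these compounds go, is whether another group on the same aromatic carbon, such as an amine, a methoxy group or a carboxylic acid, would follow the step seen on one core or the other.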